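Halophenyl swap on the carbonyl carbon: compound 3 to compound 4

A few compounds are considered here, and "the series" means these few. Any claim that something is new, unique, unknown or untested is made for them only; others in the source may bear on it.

Compound 1 `Cc1ccc(OCC(=O)NNC(=O)c2cc3ccccc3oc2=O)c(C(=O)c2cccc(Cl)c2)c1` gives 65500 nM in a functional assay on DLA cells (Mus musculus) for cytotoxicity, read by MTT assay, with a stated time of 48 h; on this read-out higher numbers stand for weaker inhibition and lower numbers for stronger inhibition; compound 2 `Cc1ccc(OCC(=O)NNC(=O)c2cc3ccccc3oc2=O)c(C(=O)c2ccc(Cl)cc2)c1` gives 59100 nM and compound 3 `Cc1ccc(OCC(=O)NNC(=O)c2cc3ccccc3oc2=O)c(C(=O)c2cccc(Br)c2)c1` gives 68500 nM. The three differ only in the halophenyl on the carbonyl carbon, and every step among them stays within the scatter: a 1.1-fold lower number from compound 1 to compound 2 (0.04 log units; within the scatter), a 1.0-fold higher number from compound 1 to compound 3 (0.02 log units; within the scatter), a 1.2-fold higher number from compound 2 to compound 3 (0.06 log units; within the scatter). Compound 3 therefore sits with compounds 1 and 2 rather than apart from them. Compound 4 `Cc1ccc(OCC(=O)NNC(=O)c2cc3ccccc3oc2=O)c(C(=O)c2ccc(F)cc2)c1` carries the change (4-fluorophenyl in place of 3-bromophenyl on a carbonyl carbon). The halogen exchange a 1.0-fold higher number from compound 1 to compound 3 (0.02 log units; within the scatter) and the ring-substitution exchange a 1.1-fold lower number from compound 1 to compound 2 (0.04 log units; within the scatter) both bear on it; neither moved the number, so no step beyond the scatter is expected in this assay, the expected step being a 1.1-fold lower number from compound 3 to compound 4 (0.02 log units; within the scatter). Compound 4 is thus estimated at 65000 nM, with a range from 35000 nM to 120000 nM.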

Compound 4, half-maximal inhibitory concentration: 43400 nM
Estimate against measurement, compound 4: 1.5-fold (0.18 log units) above, and the stated range covers the measured number.
By their numbers in this assay, from the lowest: compounds 4, 2, 1 and 3 (each within the scatter of the next).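

In this assay, 4-fluorophenyl on the carbonyl carbon stays within the scatter of all three earlier halophenyl groups: a 1.6-fold lower number from compound 3 to compound 4 (0.20 log units; within the scatter), a 1.4-fold lower number from compound 2 to compound 4 (0.13 log units; within the scatter) and a 1.5-fold lower number from compound 1 to compound 4 (0.18 log units; within the scatter). The halogen exchange at this position now covers fluoro, chloro and bromo, with no step beyond the scatter. No measured evidence bears on these numbers.

Still open, as far as these compounds go, is whether a non-halogen group on this phenyl, such as an amine or a carboxylic acid, moves the number beyond the scatter. The same question holds for a longer chain in place of the phenyl.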